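Swapping one five-membered ring for another in a solubility series

The source may hold more compounds than are shown below. What is called first, only, known or untested is meant among the compounds shown, and "the series" means these compounds.

Of the compounds shown here, three built around a shared core have been measured in a physicochemical assay for solubility, measured as kinetic solubility, at pH 2; a lower number here means a less soluble compound, a higher number a more soluble compound. Compound 1 `CC(C)[C@@H](C[C@H]1SC(=O)NC1=O)c1ccc(-c2ccc3cccc(F)c3c2)[nH]c1=O` gives 12200 nM. Compound 2 `C/C(=C1/OC(=O)NC1=O)C(c1ccc(-c2ccc3cccc(F)c3c2)[nH]c1=O)C(C)C` gives 12700 nM. Compound 3 `CC(C)C(c1ccc(-c2ccc3cccc(F)c3c2)[nH]c1=O)C1C(=O)NC(=O)N1C` gives 13600 nM. Compound 3 therefore sits alongside the other two, its gaps to compound 2 and to compound 1 both lying inside the usual scatter. The unmeasured compound 4 `CC(C)C(c1ccc(-c2ccc3cccc(F)c3c2)[nH]c1=O)C1SC(=O)NC1=O` differs from compound 3 in a single place: 2,4-dioxo-1,3-thiazolidin-5-yl in place of 3-methyl-2,5-dioxoimidazolidin-4-yl on a saturated chain carbon bound to an aromatic carbon and a saturated chain carbon. Among the measured compounds shown here, the one measured step that bears on this is a 1.1-fold higher number from compound 2 to compound 3 (0.03 log units; within the scatter), which also exchanged one five-membered non-aromatic ring with two hetero atoms for another at the same saturated chain carbon. Compound 1 carries the same 2,4-dioxo-1,3-thiazolidin-5-yl ring, though on a different chain, and its number too lies close to those of compound 2 and compound 3. The step of a 1.1-fold lower number from compound 3 to compound 4 (0.04 log units; within the scatter) is therefore expected to stay within the scatter. Compound 4 is estimated at 12500 nM, with a range from 6000 nM to 26000 nM.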

Compound 4, solubility: 11300 nM
Beside the measured number, compound 4's estimate is 1.1-fold (0.04 log units) above it; measured number inside the range.
By their numbers in this assay, from the lowest: compounds 4, 1, 2 and 3 (each within the scatter of the next).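

At the saturated chain carbon bound to an aromatic carbon and a saturated chain carbon, the exchange of 3-methyl-2,5-dioxoimidazolidin-4-yl for 2,4-dioxo-1,3-thiazolidin-5-yl now has a direct reading in this assay, which is a 1.2-fold lower number from compound 3 to compound 4 (0.08 log units; within the scatter) and so leaves the number within the scatter. The same ring, which brings in a sulfur atom, also gives a 1.1-fold lower number from compound 2 to compound 4 (0.05 log units; within the scatter), so three different five-membered non-aromatic rings at this place now give numbers that cannot be told apart. Nothing available explains this result.

All the groups at this place in these compounds are such rings with 2 hetero atoms. On these data alone, how a carboxylic acid or an amine on the same carbon would read in this assay remains open, as does whether any group there would move the number beyond the scatter.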